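The source may report more compounds than this note shows. Statements on the series, on what has been measured and on what is new or still open speak of the compounds shown alone.

Measured so far:
- compound 1 `CC1=NNC(=O)C1C(c1c(-c2ccccc2)[nH]c2ccccc12)c1c(-c2ccccc2)[nH]c2ccc(Cl)cc12` gives 41700 nM in a functional assay on HEp-2 cells (Homo sapiens) for cytotoxicity, read by MTT assay; a higher number here means a weaker inhibitor, a lower number a stronger inhibitor
- compound 2 `CC1=NNC(=O)C1C(c1c[nH]c2ccccc12)c1c(-c2ccccc2)[nH]c2ccc(C)cc12` gives 3200 nM in this assay

Within the data shown here, two measured compounds only, and they differ in more than one place, so no single-change step between them is available. Compound 2 stands at the lowest of the two numbers, and the value of compound 1 lies higher by a gap beyond the scatter, so compound 2 is the stronger of the pair in this assay.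

Compound 3 `CC1=NNC(=O)C1C(c1c[nH]c2ccccc12)c1c(-c2ccccc2)[nH]c2ccc(Cl)cc12` is the next compound, not yet measured. It is derived from compound 2 by a single change: chloro in place of methyl on an aromatic carbon. One heavy atom is exchanged for one heavy atom, with no change in ring count, donors, acceptors or charge, and the remainder of the molecule is kept intact.

Among the measured compounds shown here, no measured step of this kind exists, so the expectation rests on the smallness of the change alone. A step of modest size, in either direction, is expected, with none beyond the scatter as the most likely outcome; the expected step is a 1.3-fold higher number from compound 2 to compound 3 (0.10 log units; within the scatter). Compound 3 is estimated at 4000 nM in this assay, within a range from 1500 nM to 11000 nM.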

Compound 3, half-maximal inhibitory concentration: > 100000 nM
Compound 3 gave a limit, no number; the forecaster's own chance of this, stated with the estimate: 5%; middle value at least 25-fold (1.39 log units) away from the limit.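

Compound 3 stands at a limit of the assay and not at a number: the limit of > 100000 nM in this assay, at which 1 of the 3 values shown sits.

Even so, the carbon that carries methyl or chloro is not a silent position in this assay: exchanging one heavy atom for another, with no change in ring, donor, acceptor or charge counts, gives an at least 31-fold higher number from compound 2 to compound 3 (1.49 log units; beyond the scatter). With chloro held in place, hydrogen in place of phenyl on an aromatic carbon gives an at least 2.3-fold higher number from compound 1 to compound 3 (0.37 log units; beyond the scatter), so the phenyl also counts, and the series now has two single-change steps that both end at the same limit.

From the compounds shown here alone, how a fluoro, a methoxy or an amine on this carbon would read remains open, as does where compound 3 lies beyond its limit. Also open, going by these compounds, is whether methyl in place of chloro would keep its low number with the phenyl of compound 1 present, and whether a longer chain in place of that phenyl would read nearer to compound 1 or to compound 3.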